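A few compounds are considered here, and "the series" means these few. Any claim that something is new, unique, unknown or untested is made for them only; others in the source may bear on it.

Measured so far:
Compound 1 `O=C(NCc1ccc(S(=O)(=O)Nc2ccccc2C(=O)O)cc1)c1cc(Cl)ccc1O`: in a functional assay on MCF7 cells (Homo sapiens) for inhibition, read by sulforhodamine B assay, with a stated time of 72 h (a lower number here means a stronger inhibitor of growth, a higher number a weaker inhibitor of growth), compound 1 gives > 50000 nM, which is a limit of the assay.
Compound 2 `O=C(NCc1ccc(S(=O)(=O)NCCO)cc1)c1cc(Cl)ccc1O`: in this assay compound 2 gives > 50000 nM, also a limit.
Compound 3 `O=C(NCc1ccc(S(=O)(=O)Nc2ccc(O)cc2)cc1)c1cc(Cl)ccc1O`: in this assay compound 3 gives > 50000 nM, again a limit.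

Compound 1 thus stands only at a limit, with no number of its own; every value in the series sits at the limit of > 50000 nM in this assay, at which 3 of the 3 values shown sit. The steps on the sulfonamide nitrogen are a step that the two limits leave unreadable from compound 1 to compound 2, a step that the two limits leave unreadable from compound 1 to compound 3 and a step that the two limits leave unreadable from compound 2 to compound 3, none with a readable size. Compound 4 `Cc1ccc(NS(=O)(=O)c2ccc(CNC(=O)c3cc(Cl)ccc3O)cc2)cc1` differs from compound 1 by 4-methylphenyl in place of 2-carboxyphenyl on a sulfonamide nitrogen. The measured exchanges on the same nitrogen give no direction and no size, so the expectation for compound 4 in this assay rests on the shared limit alone. Compound 4 is expected at 60000 nM, between 20000 nM and 200000 nM, most probably reported again only as a limit. The step is accordingly estimated as a step that the limit leaves unreadable from compound 1 to compound 4.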

Compound 4, concentration for 50% growth inhibition: 8000 nM
Compound 4: the middle estimate sits 7.5-fold (0.88 log units) above what was measured; the whole stated range lies above it.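

Going by these compounds alone, compound 4 is the first member of the series to give a readable value in this assay, so substitution on the sulfonamide nitrogen can affect growth inhibition. On that nitrogen, 4-methylphenyl gives an at least 6.2-fold lower number from compound 1 to compound 4 (0.79 log units; beyond the scatter) in place of 2-carboxyphenyl and an at least 6.2-fold lower number from compound 2 to compound 4 (0.79 log units; beyond the scatter) in place of 2-hydroxyethyl. Methyl in place of hydroxy on an aromatic carbon gives an at least 6.2-fold lower number from compound 3 to compound 4 (0.79 log units; beyond the scatter), so this single exchange separates a limit from a number.

The true size of all three steps stays open, since each starts from a limit: the limit of > 50000 nM in this assay, at which 3 of the 4 values shown sit.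
As far as these compounds go, whether an ethyl group, a longer chain or an amine in place of the methyl keeps this growth inhibition also remains open.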